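A few compounds are considered here, and "the series" means these few. Any claim that something is new, unique, unknown or untested is made for them only; others in the source may bear on it.

Measured in a functional assay on SMMC-7721 cells (Homo sapiens) for antiproliferative activity, read by MTT assay, with a stated time of 72 h; a lower number here means a stronger inhibitor, a higher number a weaker inhibitor:
- compound 1 `C/C(=N\NC(=O)c1cccc(S(=O)(=O)N2CCOCC2)c1)c1cc(O)ccc1O`: > 100000 nM
- compound 2 `O=C(N/N=C/c1ccccc1O)c1cccc(S(=O)(=O)N2CCOCC2)c1`: 12100 nM
- compound 3 `CCN(CC)c1ccc(/C=N/NC(=O)c2cccc(S(=O)(=O)N3CCOCC3)c2)c(O)c1`: 27100 nM

Compound 1 reports only a limit of the assay, not a number: the limit of > 100000 nM in this assay, at which 1 of the 3 values shown sits. That leaves two true numbers, and compound 2 holds the lower one. Its nearest neighbour shows a 2.2-fold higher number from compound 2 to compound 3 (0.35 log units; beyond the scatter).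

The next compound to be tested is compound 4 `O=C(N/N=C/c1cc(Br)cc(Br)c1O)c1cccc(S(=O)(=O)N2CCOCC2)c1`. Going by the values given here, it keeps the core of compound 2 and changes only one group: 3,5-dibromo-2-hydroxyphenyl in place of 2-hydroxyphenyl on a carbon with a double bond to nitrogen. This places 3,5-dibromo-2-hydroxyphenyl in place of 2-hydroxyphenyl on a carbon with a double bond to nitrogen.

Among the compounds with values here, only one measured step offers a guide, the diethylamino change from compound 2 to compound 3, which gave a 2.2-fold higher number from compound 2 to compound 3 (0.35 log units; beyond the scatter). It involves a different group, so it gives a rough sense of size but no reliable direction. In this assay, the expected result is therefore no step beyond the scatter, though the uncertainty is wide. The estimated change is a 1.3-fold lower number from compound 2 to compound 4 (0.13 log units; within the scatter). For compound 4 the expected value is 9000 nM, with an estimated range from 2500 nM to 30000 nM.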

Compound 4, half-maximal inhibitory concentration: 7310 nM
Beside the measured number, compound 4's estimate is 1.2-fold (0.09 log units) above it; low and high end bracket the measured number.
By their numbers in this assay, from the lowest: compounds 4 and 2 (each within the scatter of the next); then compound 3. At a limit, above all of these: compound 1.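

Replacing 2-hydroxyphenyl with 3,5-dibromo-2-hydroxyphenyl on the carbon with a double bond to nitrogen gives a 1.7-fold lower number from compound 2 to compound 4 (0.22 log units; within the scatter) in this assay. This ring therefore accepts two bromine atoms with no change that can be told apart from the usual variation between repeated measurements. Going by these compounds alone, the only earlier step on this ring, the diethylamino change, did go beyond the scatter, so not every group added here leaves the number unchanged. Nothing measured here gives a cause for either step.

From the compounds shown here alone, it remains open whether one bromine atom alone would give a similar number, and whether the two bromine atoms are interchangeable with other groups. A nitro group or a carboxylic acid on this ring could still move the number beyond the scatter in either direction.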